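The compounds below may be only part of what the source reports. "The series", "measured", "known", "first", "only" and "open" are said of these compounds alone.

Measured so far in a functional assay on Jurkat cells for inhibition of nuclear factor NF-kappa-B complex (Homo sapiens); a higher number here means a weaker inhibitor, a lower number a stronger inhibitor:
compound 1 `CCOC(=O)c1cnc(-c2csc(C)n2)nc1NN1C(=O)C=C(C)C1=O`: 8000 nM
compound 2 `CCOC(=O)c1cnc(-c2ccc(C(F)(F)F)cc2)nc1NN1C(=O)C=C(C)C1=O`: 400 nM

For the measured compounds named here, of these two numbers, compound 2 holds the lower one, and the only step between them is large: a 20-fold lower number from compound 1 to compound 2 (1.30 log units; beyond the scatter). Compound 3 `CCOC(=O)c1cnc(Sc2ccccc2)nc1NN1C(=O)C=C(C)C1=O` is not yet measured; it differs from compound 2 in one place: phenylsulfanyl in place of 4-(trifluoromethyl)phenyl on an aromatic carbon. Going by the values given here, the measured step shows only that a change at this position can move the number far; no measured pair brings in a phenylsulfanyl group, so its direction is uncertain. The expected step is a 5.0-fold higher number from compound 2 to compound 3 (0.70 log units; beyond the scatter), toward a weaker inhibitor. Compound 3 is estimated at 2000 nM, between 400 nM and 10000 nM.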

Compound 3, half-maximal inhibitory concentration: 1000 nM
The estimate for compound 3 lay 2.0-fold (0.30 log units) above the measured number; the measured number falls inside the stated range.
By their numbers in this assay, from the lowest: compound 2; then compound 3; then compound 1.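

On this aromatic carbon between two ring nitrogen atoms, this assay places phenylsulfanyl in the middle of the three groups, with a 2.5-fold higher number from compound 2 to compound 3 (0.40 log units; beyond the scatter) and an 8.0-fold lower number from compound 1 to compound 3 (0.90 log units; beyond the scatter) in the same test. A benzene ring joined through sulfur therefore gives a lower number than 2-methyl-1,3-thiazol-4-yl, but 4-(trifluoromethyl)phenyl still gives the lowest number of the three. Compound 3 differs from compound 2 in both the sulfur and the missing trifluoromethyl, so this step cannot be divided between them.

A plain phenyl group or an anilino group on this carbon would help to separate those two parts. Nothing available explains the order of the three numbers.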